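Swapping the aromatic group: compound 3 to compound 4

The compounds below may be only part of what the source reports. "The series", "measured", "known", "first", "only" and "open" are said of these compounds alone.

- Compound 1 `COc1cc(OC)c(OC)cc1/C=C/COC(=O)/C=C/c1cccc(Br)c1` gives > 461 umol/kg (a limit of the assay, not a number)
- Compound 2 `COc1cc(OC)c(OC)cc1/C=C/COC(=O)/C=C/c1ccc(F)cc1` gives 449 umol/kg
- Compound 3 `COc1cccc(/C=C/C(=O)OC/C=C/c2cc(OC)c(OC)cc2OC)c1` gives 643 umol/kg

In a functional assay on the whole organism (strain Kunming) with Mus musculus as the target, with a stated time of 0.5 h (on this read-out lower numbers stand for an effect already at smaller amounts and higher numbers for an effect only at larger amounts of compound), compound 3 has one neighbour with an exact number, compound 2, and the two lie within the scatter of each other. Compound 4 `COc1cc(OC)c(OC)cc1/C=C/COC(=O)/C=C/c1ccc(Cl)cc1` takes 4-chlorophenyl in place of the 3-methoxyphenyl of compound 3 4-chlorophenyl in place of 3-methoxyphenyl on a double-bonded chain carbon bound to a double-bonded chain carbon on a double-bonded chain carbon bound to a double-bonded chain carbon.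

Two measured swaps at that same place bear on this change. One is a 1.4-fold higher number from compound 2 to compound 3 (0.16 log units; within the scatter) and the other is an at least 1.0-fold lower number from compound 1 to compound 2 (0.01 log units; that floor lies within the scatter) with its size known only as a floor. Neither shows a change beyond the scatter, and only these three compounds stand behind that reading. No step beyond the scatter is therefore expected in this assay, so the estimated move a 1.3-fold lower number from compound 3 to compound 4 (0.13 log units; within the scatter) is a small one without a firm direction. Compound 4 is expected at 480 umol/kg (estimated range from 260 umol/kg to 880 umol/kg).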

Compound 4, dose for half-maximal effect: 364 umol/kg
Estimate against measurement, compound 4: 1.3-fold (0.12 log units) above, within the range that was stated.
By their numbers in this assay, from the lowest: compounds 4, 2 and 3 (each within the scatter of the next).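

Measured in this assay, 4-chlorophenyl in place of 3-methoxyphenyl gives a 1.8-fold lower number from compound 3 to compound 4 (0.25 log units; within the scatter) and chloro in place of fluoro gives a 1.2-fold lower number from compound 2 to compound 4 (0.09 log units; within the scatter) and so neither change to the aromatic group at this place separates from the scatter. Set against the 3-bromophenyl of compound 1, compound 4 shows an at least 1.2-fold lower number from compound 1 to compound 4 (0.10 log units; that floor lies within the scatter) and this step is known only as a floor. Only a floor can be read because compound 1 stands at a limit of the assay and not at a number: the limit of > 461 umol/kg in this assay, at which 1 of the 4 values shown sits.

All four compounds carry a substituted phenyl group here on the same shared core. As far as these compounds go, whether an amine or a carboxylic acid on that phenyl group would move the number beyond the scatter remains open.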